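This account rests on a few compounds, and the source may have more. Where it says the series, first, only, none or still open, it means among the compounds named here.

Compound 2 `Cc1cccc(NC(=O)Nc2c(-c3ccccc3)c3cc(C)c(C)cc3c(=O)n2C)c1` stands at the weaker end of the two numbers measured in an assay on IM-9 cells for binding affinity to Substance-P receptor (Homo sapiens); a higher number here means a weaker inhibitor, a lower number a stronger inhibitor: in this assay compound 2 gives 840 nM, the highest of the two. Compound 1 `Cc1cc(C)cc(CN(C)C(=O)Nc2c(-c3ccccc3)c3cc(C)c(C)cc3c(=O)n2C)c1` gives 28 nM in this assay, and the step of a 30-fold higher number from compound 1 to compound 2 (1.48 log units; beyond the scatter) shows how much was lost when (3-methylphenyl)amino replaced (3,5-dimethylbenzyl)(methyl)amino on the carbonyl carbon.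

Compound 3 `COc1ccccc1CN(C)C(=O)Nc1c(-c2ccccc2)c2cc(C)c(C)cc2c(=O)n1C` moves in the opposite direction: (2-methoxybenzyl)(methyl)amino in place of (3-methylphenyl)amino on a carbonyl carbon. This restores a benzyl(methyl)amino arrangement of the kind present in compound 1, though the ring now carries a methoxy group rather than two methyl groups. Because the step of a 30-fold higher number from compound 1 to compound 2 (1.48 log units; beyond the scatter) was large, a large return toward stronger binding is expected for compound 3, but the different ring substituent adds uncertainty.

For compound 3 the expected value in this assay is 50 nM, with a likely range from 12 nM to 250 nM, a step of a 17-fold lower number from compound 2 to compound 3 (1.23 log units; beyond the scatter) that is estimated, not measured.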

Compound 3, half-maximal inhibitory concentration: 23 nM
Estimate against measurement, compound 3: 2.2-fold (0.34 log units) above; measured number inside the range.
By their numbers in this assay, from the lowest: compounds 3 and 1 (each within the scatter of the next); then compound 2.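

The step of a 37-fold lower number from compound 2 to compound 3 (1.56 log units; beyond the scatter) in this assay shows that the large loss seen with (3-methylphenyl)amino is not tied to the exact ring of compound 1, since (2-methoxybenzyl)(methyl)amino on the same carbonyl carbon brings the number back down. The step of a 1.2-fold lower number from compound 1 to compound 3 (0.09 log units; within the scatter) lies within the scatter, so 2-methoxyphenyl and 3,5-dimethylphenyl cannot be told apart at this position. Nothing measured here explains why these groups give these numbers.

The change from compound 2 to compound 3 alters the nitrogen substitution, the added saturated chain carbon and the ring substituents all at once, so the part responsible for the gain remains unresolved. Also open, as far as these compounds go, is how this position would respond to a benzyl ring carrying a chlorine atom or a hydroxyl group.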